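A few compounds are considered here, and "the series" means these few. Any claim that something is new, unique, unknown or untested is made for them only; others in the source may bear on it.

Compound 1 `O=C(C1CCCC1)N1N=CCC1c1ccccc1`: 1.13 h
Compound 2 `CC(C)(CO)C(=O)N1N=CCC1c1ccccc1`: > 1.5 h

Both compounds were measured in an ADME assay on microsomes (Homo sapiens) for metabolic stability (on this read-out higher numbers stand for a longer-lived compound and lower numbers for a shorter-lived compound), and they differ only in the group on the carbonyl carbon. Compound 1 gives a true number there, 1.13 h. Compound 2 has no exact number, and its entry is a limit of the assay: the limit of > 1.5 h in this assay, at which 1 of the 2 values shown sits.

The next compound is compound 3 `O=C(C1CCOCC1)N1N=CCC1c1ccccc1`, which has oxan-4-yl in place of 1-(hydroxymethyl)-1-methylethyl on a carbonyl carbon. The new group brings a six-membered non-aromatic ring to the same place and removes the hydrogen-bond donor.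

Going by the values given here, only one measured step bears on this change: an at least 1.3-fold higher number from compound 1 to compound 2 (0.12 log units; that floor lies within the scatter). It also swaps the group on the carbonyl carbon, with cyclopentyl as the group that leaves. That step is small, so no step beyond the scatter is expected in this assay, in either direction. The expected step is a number no higher from compound 2 to compound 3 (the limit leaves the size open). The estimated half-life of compound 3 is 1.5 h, with an expected range from 0.9 h to 2.4 h.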

Compound 3, half-life: > 1.5 h
Compound 3 ended at the assay's limit (the forecaster's own chance of this, stated with the estimate: 50%); the middle value lies on the limit itself.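

Compound 3 also sits at a limit of the assay, not at a true number: the limit of > 1.5 h in this assay, at which 2 of the 3 values shown sit.

A second kind of group on a carbonyl carbon, oxan-4-yl with its six-membered non-aromatic ring and 0 hydrogen-bond donors, thus reaches the same limit as 1-(hydroxymethyl)-1-methylethyl, which shows that the hydrogen-bond donor of compound 2 is not needed to reach that limit in this assay. Against cyclopentyl, the readable change is an at least 1.3-fold higher number from compound 1 to compound 3 (0.12 log units; that floor lies within the scatter), so the true gap could be larger, but its printed floor does not establish a real gain over compound 1; the step linking the two limit entries cannot be read at all.

From the compounds shown here alone, with no exact half-life for either compound, how far compound 2 and compound 3 stand apart remains open. Also open, going by these compounds, is whether the ring oxygen of oxan-4-yl matters, a question that cyclohexyl, the six-membered ring of carbon alone, or piperidin-4-yl, with a ring nitrogen in place of that oxygen, could address.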